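The source may hold more compounds than are shown below. What is called first, only, known or untested is meant among the compounds shown, and "the series" means these compounds.

In a functional assay on A549 cells (Homo sapiens) for inhibition, read by MTT assay, with a stated time of 24 h (on this read-out lower numbers stand for stronger inhibition and higher numbers for weaker inhibition), compound 1 `CC1(C)[C@H]2CC[C@]1(C)N(Cc1cn(-c3ccc(F)cc3)nn1)C(=O)C2` gives 230 nM. Compound 2 `COc1ccccc1-n1cc(CN2C(=O)C[C@@H]3CC[C@@]2(C)C3(C)C)nn1` gives 350 nM in this assay, and the step of a 1.5-fold higher number from compound 1 to compound 2 (0.18 log units; within the scatter) leaves the two within the scatter of each other. Compound 3 `COc1ccc(-n2cc(CN3C(=O)C[C@@H]4CC[C@@]3(C)C4(C)C)nn2)cc1` differs from compound 2 by 4-methoxyphenyl in place of 2-methoxyphenyl on an aromatic nitrogen. Among the measured compounds shown here, no measured step compares these two groups directly. For the measured compounds named here, the only change made so far at this aromatic nitrogen, a 1.5-fold higher number from compound 1 to compound 2 (0.18 log units; within the scatter), stayed within the scatter. Compound 3 is therefore expected to show a step of a 1.2-fold lower number from compound 2 to compound 3 (0.07 log units; within the scatter), none beyond the scatter. For compound 3 the estimate in this assay is 300 nM, ranging from 120 nM to 800 nM.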

Compound 3, half-maximal inhibitory concentration: 50 nM
Compound 3: the middle estimate sits 6.0-fold (0.78 log units) above what was measured; measured number outside the range, below it.
By their numbers in this assay, from the lowest: compound 3; then compounds 1 and 2 (each within the scatter of the next).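

At this aromatic nitrogen, the arrangement of the same atoms now matters: 4-methoxyphenyl in place of 2-methoxyphenyl gives a 7.0-fold lower number from compound 2 to compound 3 (0.85 log units; beyond the scatter) in this assay, which the earlier pair, whose difference stayed within the scatter, did not show. Methoxy in place of fluoro on an aromatic carbon gives a 4.6-fold lower number from compound 1 to compound 3 (0.66 log units; beyond the scatter), so compound 3 stands apart from both earlier compounds. Nothing available explains why these changes have such effects.

On these data alone, it remains open whether a longer chain such as ethoxy, an amine or a carboxylic acid in place of that methoxy would keep this stronger inhibition.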